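This account rests on a few compounds, and the source may have more. Where it says the series, first, only, none or still open, it means among the compounds named here.

This study follows a small set of purine-like compounds built on a shared core, tested in an ADME assay on CCRF-HSB-2 cells (Homo sapiens) for cytotoxicity, with a stated time of 7 days; a lower number here means that less compound is tolerated, a higher number that more compound is tolerated. Compound 1 has the structure `CNc1nc(N)nc2c1ncn2/C=C1/CC1(CO)CO`. In this assay compound 1 gives > 20000 nM, which is a limit of the assay rather than a measured number. Compound 2, with the structure `Nc1nc(NCc2ccccc2)c2ncn(/C=C3/CC3(CO)CO)c2n1`, is the one measured partner that differs from compound 1 in a single place. In this assay compound 2 also gives > 20000 nM, again a limit. Within the data shown here, the step that the two limits leave unreadable from compound 1 to compound 2 therefore cannot be read in size, and the only evidence so far is the limit of > 20000 nM in this assay, at which 2 of the 2 values shown sit.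

Compound 3 is the new, unmeasured member, with the structure `Nc1nc(SC2CCCC2)c2ncn(/C=C3/CC3(CO)CO)c2n1`. Its change from compound 1 is cyclopentylsulfanyl in place of methylamino on an aromatic carbon. Among the measured compounds shown here, no measured step involves a cyclopentylsulfanyl group, and the single step that is known is unreadable, so there is no basis for expecting a step beyond the scatter in either direction. Compound 3 is expected to give about 20000 nM, within a range from 6000 nM to 60000 nM. That estimate corresponds to an expected step of a number no higher from compound 1 to compound 3 (the limit leaves the size open).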

Compound 3, half-maximal cytotoxic concentration: 91000 nM
Beside the measured number, compound 3's estimate is 4.6-fold (0.66 log units) below it, and the stated range ends below it.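

Compound 1 and compound 2 are known in this assay only as limits, not as numbers, and the steps from each of them to compound 3 cannot be read. The compounds shown leave open how far, and in which direction, cyclopentylsulfanyl differs from methylamino or benzylamino at this place on the shared core.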